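This account rests on a few compounds, and the source may have more. Where it says the series, first, only, none or still open, it means among the compounds named here.

Going by the values given here, compound 1 `FC(F)(F)c1ccc(Nc2ncnc3sc(Nc4c(Cl)cccc4Cl)nc23)cc1` holds the lower number of the two measured members in a functional assay on HEK293 cells for antagonist activity at transient receptor potential cation channel subfamily V member 1 (Homo sapiens), read by calcium flux; on this read-out higher numbers stand for weaker inhibition and lower numbers for stronger inhibition: compound 1 gives 12 nM, while compound 2 `CS(=O)(=O)c1ccccc1Nc1nc2c(Nc3ccc(C(F)(F)F)cc3)ncnc2s1` gives 234 nM, and the single comparable step, a 20-fold higher number from compound 1 to compound 2 (1.29 log units; beyond the scatter), concerns the aryl group on the exocyclic nitrogen rather than the shared core.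

Compound 3 `CN(C)c1nc(Nc2ccc(C(F)(F)F)cc2)c2nc(Nc3c(Cl)cccc3Cl)sc2n1` keeps the 2,6-dichlorophenyl of compound 1 and differs from it only at the core: dimethylamino in place of hydrogen on an aromatic carbon. Among the compounds with values here, no measured step touches this carbon, so the one step in hand, from compound 1 to compound 2, gives no direct guide to the size or direction of the change in this assay. Without such a precedent the expectation for compound 3 is a step of a 1.7-fold higher number from compound 1 to compound 3 (0.22 log units; within the scatter), close to no change beyond the scatter but with a wide margin either way. Compound 3 is therefore estimated at 20 nM in this assay, with a range from 4 nM to 120 nM.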

Compound 3, half-maximal inhibitory concentration: 59 nM
The estimate for compound 3 lay 3.0-fold (0.47 log units) below the measured number, and the stated range covers the measured number.
By their numbers in this assay, from the lowest: compound 1; then compound 3; then compound 2.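

The aromatic carbon between two ring nitrogen atoms is not a neutral position in this assay: dimethylamino in place of hydrogen there gives a 4.9-fold higher number from compound 1 to compound 3 (0.69 log units; beyond the scatter). Going by these compounds alone, this is the first measured change at the shared core, and it is smaller than the step at the aryl group on the exocyclic nitrogen, a 20-fold higher number from compound 1 to compound 2 (1.29 log units; beyond the scatter). Nothing at hand explains why the number rises at this carbon.

Going by these compounds, with only hydrogen and dimethylamino compared at this carbon, it remains open whether an amino group, a methylamino group, a methoxy group or a morpholine ring would give a similar step. On these data alone, it is also open whether the step from dimethylamino would be of the same size with the 2-(methylsulfonyl)phenyl group of compound 2 in place of 2,6-dichlorophenyl.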